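The source may report more compounds than this note shows. Statements on the series, on what has been measured and on what is new or still open speak of the compounds shown alone.

For the measured compounds named here, in a physicochemical assay for solubility, read by spectrophotometry, in phosphate buffer, with a stated time of 18 h, at pH 7.4 (a lower number here means a less soluble compound, a higher number a more soluble compound), compound 3 `CCc1ccc(-c2nc3c(c(C)nn3-c3ccccc3)c(-c3ccccc3C(=O)O)c2C#N)cc1` gives 33000 nM, the highest number so far, compared with compound 1 `CCc1ccc(-c2nc3c(c(C)nn3-c3ccccc3)c(-c3ccccc3C#N)c2C#N)cc1` at 2400 nM and compound 2 `CCc1ccc(-c2nc3c(c(C)nn3-c3ccccc3)c(-c3ccccc3F)c2C#N)cc1` at 1700 nM. Compound 4 `CCc1ccc(-c2nc3c(c(C)nn3-c3ccccc3)c(-c3cccc(O)c3)c2C#N)cc1` changes one place of compound 3: 3-hydroxyphenyl in place of 2-carboxyphenyl on an aromatic carbon. In short, 3-hydroxyphenyl stands in place of 2-carboxyphenyl, so the carboxy group is gone. Two measured steps that bring in carboxy bear on this, both large: a 14-fold higher number from compound 1 to compound 3 (1.14 log units; beyond the scatter) and a 19-fold higher number from compound 2 to compound 3 (1.29 log units; beyond the scatter). Fluoro in place of cyano gave only a 1.4-fold lower number from compound 1 to compound 2 (0.15 log units; within the scatter). Going by the values given here, no hydroxy compound has been measured, so this comparison is indirect. A large step down in this assay is therefore expected, estimated as an 11-fold lower number from compound 3 to compound 4 (1.04 log units; beyond the scatter). The expected value for compound 4 is 3000 nM, with an estimated range from 1000 nM to 9000 nM.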

Compound 4, solubility: 18000 nM
Estimate against measurement, compound 4: 6.0-fold (0.78 log units) below; measured number outside the range, above it.
By their numbers in this assay, from the lowest: compounds 2 and 1 (each within the scatter of the next); then compounds 4 and 3 (each within the scatter of the next).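

In this assay, 3-hydroxyphenyl on this aromatic carbon keeps the number close to that of the carboxy compound, with a 1.8-fold lower number from compound 3 to compound 4 (0.26 log units; within the scatter) and no carboxy group present. Compound 4 also stands clear of the nitrile and fluoro compounds, with an 11-fold higher number from compound 2 to compound 4 (1.02 log units; beyond the scatter) and a 7.5-fold higher number from compound 1 to compound 4 (0.88 log units; beyond the scatter), so at this position a high number does not depend on a carboxy group. No measured evidence explains this result. The compounds shown leave open whether the hydroxy group itself or its place on the phenyl ring matters, as this change alters both. As far as these compounds go, how an amine or a methoxy group on that ring would read also remains open.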